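Adding Hydroxy to an Aromatic Carbon of Compound 2

The source may report more compounds than this note shows. Statements on the series, on what has been measured and on what is new or still open speak of the compounds shown alone.

In a functional assay on K562 cells (Homo sapiens) for cytotoxicity (on this read-out lower numbers stand for stronger inhibition of growth and higher numbers for weaker inhibition of growth), compound 1 (`OCC#Cc1ccccc1C#Cc1ccccc1`) gives 26000 nM and compound 2 (`OCCCCC#Cc1ccccc1C#Cc1ccccc1`) gives 21100 nM, while compound 3 (`CSc1ccccc1C#Cc1ccccc1C#CCCCCO`) gives 6100 nM. Compound 2 thus stands in the middle of the three numbers, level with compound 1 and clear of compound 3. Compound 4 (`OCCCCC#Cc1ccccc1C#Cc1cccc(O)c1`) differs from compound 2 by hydroxy in place of hydrogen on an aromatic carbon. The chain change, a 1.2-fold lower number from compound 1 to compound 2 (0.09 log units; within the scatter), bears little on this. Among the compounds with values here, the nearest precedent, also on an aromatic carbon but with a different group, is a 3.5-fold lower number from compound 2 to compound 3 (0.54 log units; beyond the scatter). A modest change toward stronger inhibition is therefore expected, namely a 1.8-fold lower number from compound 2 to compound 4 (0.25 log units; within the scatter). The estimated value for compound 4 is 12000 nM, with an expected range from 5000 nM to 26000 nM.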

Compound 4, concentration for 50% growth inhibition: 19200 nM
The estimate for compound 4 lay 1.6-fold (0.20 log units) below the measured number; the range from low to high includes it.
By their numbers in this assay, from the lowest: compound 3; then compounds 4, 2 and 1 (each within the scatter of the next).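

In this assay, hydroxy on an aromatic carbon, meta to a large group, leaves compound 4 level with its parent (a 1.1-fold lower number from compound 2 to compound 4 (0.04 log units; within the scatter)). Thus the change from phenyl to 3-hydroxyphenyl does not bring the beyond-scatter step seen with methylsulfanyl (a 3.5-fold lower number from compound 2 to compound 3 (0.54 log units; beyond the scatter)). No available evidence accounts for this result. The compounds shown leave open whether methoxy or an amine in this same place would move the number. They also leave open whether hydroxy here would behave alike on the shorter chain of compound 1.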